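The source may report more compounds than this note shows. Statements on the series, on what has been measured and on what is new or still open speak of the compounds shown alone.

Within the data shown here, in a functional assay on the whole organism for inhibition, with Mythimna separata as the target, with a stated time of 5 days (on this read-out lower numbers stand for an effect already at smaller amounts and higher numbers for an effect only at larger amounts of compound), compound 2, `CC(C)(C)n1ncc(OCc2nnc(-c3cccc(F)c3)o2)c(Cl)c1=O`, gives 7100 nM and is the only compound here with a measured number. Compound 1, `CCCCn1ncc(OCc2nnc(-c3ccccc3)o2)c(Cl)c1=O`, gives > 299000 nM in this assay, and this is a limit of the assay rather than a number, recorded as the limit of > 299000 nM in this assay, at which 1 of the 2 values shown sits. Compound 3, `CC(C)(C)n1ncc(OCc2nnc(-c3ccccc3)o2)c(Cl)c1=O`, has not yet been measured in this assay. It differs from compound 2 by hydrogen in place of fluoro on an aromatic carbon, or, read one bond further out, 3-fluorophenyl to phenyl. Among the measured compounds shown here, no pair of measured compounds differs in exactly one place, so there is no measured step to lean on. From the structural change alone, the removal of a single fluorine, only a small step is expected, likely within or just beyond the usual scatter, and if it moves at all it is expected to move toward a larger amount of compound needed. The step expected from compound 2 to compound 3 is a 1.7-fold higher number from compound 2 to compound 3 (0.23 log units; within the scatter). Compound 3 is therefore estimated at 12000 nM, with a range from 4000 nM to 40000 nM.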

Compound 3, half-maximal effective concentration: 12200 nM
Estimate against measurement, compound 3: 1.0-fold (0.01 log units) below; measured number inside the range.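

In this assay, putting hydrogen in place of fluoro on the aromatic carbon gives a 1.7-fold higher number from compound 2 to compound 3 (0.24 log units; within the scatter), so compound 2 and compound 3 cannot be told apart, and this one fluoro makes no readable difference at this position. Among these compounds, the first comparison at the aromatic nitrogen, tert-butyl in place of butyl, gives an at least 24-fold lower number from compound 1 to compound 3 (1.38 log units; beyond the scatter), so the group on that nitrogen separates these compounds far more clearly than the fluoro does. The reading for compound 1 is a limit of the assay and not a number: the limit of > 299000 nM in this assay, at which 1 of the 3 values shown sits.

The compounds shown leave open whether a chloro or a methoxy group on the phenyl would read differently from fluoro and hydrogen. They also leave open whether the tert-butyl reading would hold with an isopropyl or a cyclohexyl group on the aromatic nitrogen, which would help show how much of the large step belongs to the branched chain itself.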